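The source may hold more compounds than are shown below. What is called first, only, known or untested is meant among the compounds shown, and "the series" means these compounds.

Measured so far in a functional assay on UACC-62 cells (Homo sapiens) for inhibition, read by sulforhodamine B assay, with a stated time of 48 h; on this read-out lower numbers stand for stronger inhibition of growth and higher numbers for weaker inhibition of growth:
- compound 1 `S=C(N/N=C/c1cccs1)Nc1ccc(Cl)cc1`: 15800 nM
- compound 2 `S=C(N/N=C/c1cccs1)Nc1ccccc1`: > 100000 nM (a limit, not a number)
- compound 3 `COc1ccc(NC(=S)N/N=C/c2cccs2)cc1`: > 100000 nM (a limit, not a number)

Compound 3 stands at the limit of > 100000 nM in this assay, at which 2 of the 3 values shown sit, so it has a limit rather than a true number. Compound 2 shares that limit, which leaves a step that the two limits leave unreadable from compound 2 to compound 3. Compound 1 is the only one of the three with a true number.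

The next compound is compound 4 `S=C(N/N=C/c1cccs1)Nc1ccc(Br)cc1`. The change is bromo in place of methoxy on an aromatic carbon, para to a large group.

Within the data shown here, two measured steps bear on this. One is an at least 6.3-fold higher number from compound 1 to compound 3 (0.80 log units; beyond the scatter), with methoxy in place of chloro. The other is an at least 6.3-fold higher number from compound 1 to compound 2 (0.80 log units; beyond the scatter), with hydrogen in place of chloro. Among the measured compounds shown here, both lie beyond the scatter, and in these three compounds only the one carrying chloro gives a true number. Bromo has not yet been measured at this place, so reading across from chloro is an assumption. If it holds, the move away from methoxy should lower the number by a step of similar size, and the expected result is an at least 6.2-fold lower number from compound 3 to compound 4 (0.79 log units; beyond the scatter). Compound 4 is estimated at 16000 nM, with an expected range of 5000 nM to 60000 nM.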

Compound 4, concentration for 50% growth inhibition: 71100 nM
Compound 4: the middle estimate sits 4.4-fold (0.65 log units) below what was measured; the whole stated range lies below it.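

Bromo gives compound 4 a true number in this assay, so among the four compounds shown, the two with a halogen at this place, para to a large group, give true numbers, while hydrogen and methoxy give only limits. Among these compounds, the two halogens are not interchangeable, though, since swapping chloro for bromo produces a 4.5-fold higher number from compound 1 to compound 4 (0.65 log units; beyond the scatter), a real loss of growth inhibition that the earlier compounds could not reveal. The gain from placing bromo here is harder to size, as the comparisons with methoxy and hydrogen give only an at least 1.4-fold lower number from compound 3 to compound 4 (0.14 log units; that floor lies within the scatter) and an at least 1.4-fold lower number from compound 2 to compound 4 (0.14 log units; that floor lies within the scatter), and these are minimum sizes rather than measured gaps: the limit of > 100000 nM in this assay, at which 2 of the 4 values shown sit.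

As far as these compounds go, the true distance from compound 4 to compound 2 and compound 3 remains unknown, and the step between compound 2 and compound 3 cannot be read at all. From the compounds shown here alone, it also remains open whether the ranking of chloro over bromo extends to other groups at this place, such as fluoro, iodo, trifluoromethyl or an amine, or whether it holds only for this pair.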